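The source may report more compounds than this note shows. Statements on the series, on what has been measured and on what is new or still open speak of the compounds shown alone.

Compound 1 `COc1cccc(NC(=S)Nc2cccc(C(F)(F)F)c2)c1`: 12000 nM
Compound 2 `C=C(C)CNC(=S)Nc1cccc(C(F)(F)F)c1`: > 100000 nM

Both compounds were tested in an ADME assay on BHK cells (Mesocricetus auratus) for cytotoxicity, read by MTT assay, with a stated time of 96 h (on this read-out lower numbers stand for higher toxicity in this test and higher numbers for lower toxicity in this test), so a drop in the number would point to a more toxic compound. In this assay, compound 2 gives > 100000 nM, which is a limit of the assay and not a number. Its exact position is therefore unknown.

The next compound to be tested is compound 3 `Fc1cccc(NC(=S)Nc2cccc(C(F)(F)F)c2)c1`. It has 3-fluorophenyl in place of 2-methylprop-2-en-1-yl on an amide-type nitrogen. The new group brings a six-membered aromatic ring of carbon only to that nitrogen. Compound 1 also has such a ring there, and compound 1 gives 12000 nM, so it is the closest guide available.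

A large fall in the number is expected in this assay, well beyond the usual scatter and towards higher toxicity in this test. The expected change is an at least 6.6-fold lower number from compound 2 to compound 3 (0.82 log units; beyond the scatter), although its true size remains uncertain with only a limit as the starting point. For compound 3, the estimated value is 15000 nM. The expected range for compound 3 runs from 5000 nM to 50000 nM.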

Compound 3, half-maximal cytotoxic concentration: 9400 nM
For compound 3 the middle estimate is 1.6-fold (0.20 log units) above the measured one; the range from low to high includes it.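

In this assay, going by these compounds alone, the earlier compounds gave no measured step at this nitrogen, and now putting 3-fluorophenyl in place of 2-methylprop-2-en-1-yl gives an at least 10-fold lower number from compound 2 to compound 3 (1.02 log units; beyond the scatter), so this position clearly matters for the read-out. On these data alone, the true size of that step stays unknown because compound 2 stands at a limit of the assay, not at a number: the limit of > 100000 nM in this assay, at which 1 of the 3 values shown sits. Fluoro in place of methoxy on an aromatic carbon gives a 1.3-fold lower number from compound 1 to compound 3 (0.11 log units; within the scatter), so among these two compounds that carry a ring at this nitrogen, the choice between the two ring substituents makes no difference that can be told from the usual scatter.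

The compounds shown leave open whether the aromatic ring itself is what counts, or whether another group at that nitrogen, such as a cyclohexyl ring or a longer carbon chain, would bring the number down in the same way. They also leave open whether a different substituent on the aromatic ring, such as an amine or a carboxylic acid, would keep the number where compound 1 and compound 3 stand.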